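This account rests on a few compounds, and the source may have more. Where it says the series, first, only, none or still open, it means among the compounds named here.

Measured so far in this series:
compound 1 `O=C1CSC(c2ccc(Cl)cc2)N1CCN1CCCCC1`: 68%
compound 2 `O=C1CSC(c2ccccc2Cl)N1CCN1CCCCC1`: 71%
compound 3 `COc1cccc(C2SCC(=O)N2CCN2CCCCC2)c1`: 66%

In an ADME assay on Vero cells (Chlorocebus sabaeus) for cytotoxicity, read by neutral red uptake, tested at 197 ug/mL (a lower number here means a stronger effect, a higher number a weaker effect of the compound at the concentration tested), compound 3 holds the lowest of the three numbers, but all three lie within the scatter of one another. Nearest stands compound 1 with 68%. Furthest stands compound 2 with 71%.

Compound 4 `O=C1CSC(c2cccc(Cl)c2)N1CCN1CCCCC1` differs from compound 3 by chloro in place of methoxy on an aromatic carbon. Among the compounds with values here, the one measured step, a number 3 percentage points higher from compound 1 to compound 2 (within the scatter), shifts the chloro between aromatic carbons and stays within the scatter. Within the data shown here, no measured step exchanges methoxy for chloro alone; compound 3 and compound 1 differ in the group and in its place, and their values fall within the scatter. The step from compound 3 to compound 4 is therefore expected to stay within the scatter, a number 3 percentage points higher from compound 3 to compound 4 (within the scatter). Compound 4 is estimated at 69%, range 60% to 78%.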

Compound 4, a percentage reported as activity, at one concentration (the size of the read-out at that concentration, not a potency): 77%
Estimate against measurement, compound 4: 8 percentage points below; low and high end bracket the measured number.
By their numbers in this assay, from the lowest: compounds 3, 1, 2 and 4 (each within the scatter of the next, the first and the last beyond it).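

Chloro in place of methoxy on an aromatic carbon gives a number 11 percentage points higher from compound 3 to compound 4 (beyond the scatter) in this assay and is the first step in the series to pass the scatter. Moving the chloro alone gives a number 6 percentage points higher from compound 2 to compound 4 (within the scatter) and a number 9 percentage points higher from compound 1 to compound 4 (within the scatter) and so does not separate the three chloro compounds, which places the only clear difference at this exchange of groups on the same aromatic carbon. No measured evidence bears on this result.

On these data alone, whether the step is particular to chloro and methoxy stays open, as an amine or a carboxylic acid on this aromatic carbon could show. As far as these compounds go, whether methoxy in the other two places on the ring gives a step of this size also stays open.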